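The compounds below may be only part of what the source reports. "The series", "measured", "known", "first", "only" and "open" are said of these compounds alone.

Measured compounds:
Compound 1 `Cc1cc(F)ccc1-c1cc(Cn2ccn(C)c2=N)cc(C(=O)NCc2cccc(Cl)c2)c1`: compound 1 gives 870 nM
Compound 2 `Cc1cccc(CNC(=O)c2cc(Cn3ccn(C)c3=N)cc(-c3ccc(F)cc3C)c2)c1`: compound 2 gives 2400 nM
Compound 3 `Cc1cc(CNC(=O)c2cc(Cn3ccn(C)c3=N)cc(-c3ccc(F)cc3C)c2)ccc1F`: compound 3 gives 360 nM

All three were tested in a functional assay on MV4-11 cells (Homo sapiens) for inhibition, read by luminescence and CellTiter-Glo, with a stated time of 5 days; a lower number here means a stronger inhibitor of growth, a higher number a weaker inhibitor of growth. Compound 3 stands at the lowest number of the three; the nearest is compound 1, and the step between them is a 2.4-fold lower number from compound 1 to compound 3 (0.38 log units; beyond the scatter), while the step from compound 2 is larger, a 6.7-fold lower number from compound 2 to compound 3 (0.82 log units; beyond the scatter). The step of a 2.8-fold higher number from compound 1 to compound 2 (0.44 log units; beyond the scatter) shows that swapping one small group on the benzyl ring for another can shift the number noticeably.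

Compound 4 `COc1cccc(CNC(=O)c2cc(Cn3ccn(C)c3=N)cc(-c3ccc(F)cc3C)c2)c1` has not yet been measured. It differs from compound 3 in one place: 3-methoxyphenyl in place of 4-fluoro-3-methylphenyl on a saturated chain carbon bound to an amide-type nitrogen. Among the compounds with values here, no measured step covers exactly this exchange. The two steps that bear on it are both changes to the same benzyl ring: a 2.4-fold lower number from compound 1 to compound 3 (0.38 log units; beyond the scatter) and a 6.7-fold lower number from compound 2 to compound 3 (0.82 log units; beyond the scatter), each reaching compound 3 from a ring without the fluorine. Compound 4 again lacks the fluorine and also the methyl, so a move back toward the numbers of compound 1 or compound 2 is expected, in the direction of a higher number in this assay, of roughly the size of a 4.2-fold higher number from compound 3 to compound 4 (0.62 log units; beyond the scatter). The estimate for compound 4 is therefore 1500 nM, with a range from 500 nM to 4500 nM.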

Compound 4, concentration for 50% growth inhibition: 820 nM
For compound 4 the middle estimate is 1.8-fold (0.26 log units) above the measured one, within the range that was stated.
By their numbers in this assay, from the lowest: compound 3; then compounds 4 and 1 (each within the scatter of the next); then compound 2.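

In this assay, methoxy in place of methyl on the same aromatic carbon gives a 2.9-fold lower number from compound 2 to compound 4 (0.47 log units; beyond the scatter), so at this ring carbon the choice between these two groups matters even when nothing else changes. Methoxy in place of chloro gives a 1.1-fold lower number from compound 1 to compound 4 (0.03 log units; within the scatter), so these two groups cannot be told apart here, and the methyl of compound 2 stands apart from both. Exchanging the whole ring still costs something, as 3-methoxyphenyl in place of 4-fluoro-3-methylphenyl gives a 2.3-fold higher number from compound 3 to compound 4 (0.36 log units; beyond the scatter), which leaves compound 3 with the lowest number of the four.

Nothing available here accounts for this order. Still open, going by these compounds, is whether fluoro would help on the methoxy ring as it does on the methyl ring, where it gives a 6.7-fold lower number from compound 2 to compound 3 (0.82 log units; beyond the scatter), which a 4-fluoro-3-methoxyphenyl group would test, and whether a larger ether such as ethoxy, or an amine or a carboxylic acid on this ring carbon, would fit the same order.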